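USP7 inhibitors: swapping a five-membered heteroaryl ring

This account rests on a few compounds, and the source may have more. Where it says the series, first, only, none or still open, it means among the compounds named here.

Measured compounds:
- compound 1 `Cn1nc2c(=O)n(CC3(O)CCN(Cc4ccc(C5CCCO5)cc4Cl)CC3)cnc2c1-c1ccc(CN)cc1`: 3820 nM
- compound 2 `Cn1nc2c(=O)n(CC3(O)CCN(Cc4ccc(-c5ccc[nH]5)cc4Cl)CC3)cnc2c1-c1ccc(CN)cc1`: 193 nM
- compound 3 `Cn1nc2c(=O)n(CC3(O)CCN(Cc4ccc(-c5ccco5)cc4Cl)CC3)cnc2c1-c1ccc(F)cc1`: 64.5 nM

All three compounds share one core and were tested in an assay on isolated protein for inhibition of ubiquitin carboxyl-terminal hydrolase 7 (Homo sapiens), with stated times of 30 min and 2 h; a higher number here means a weaker inhibitor, a lower number a stronger inhibitor. Compound 2 stands second highest of the three numbers: compound 3 lies a moderate way below it, while compound 1 lies far above it, both gaps beyond the scatter. Within the data shown here, the one directly comparable step, a 20-fold lower number from compound 1 to compound 2 (1.30 log units; beyond the scatter), shows that replacing a saturated ring by a five-membered aromatic ring at this position brought a large gain in potency.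

Compound 4 `Cn1nc2c(=O)n(CC3(O)CCN(Cc4ccc(-c5ccsc5)cc4Cl)CC3)cnc2c1-c1ccc(CN)cc1` is the next compound to be examined. It differs from compound 2 by thiophen-3-yl in place of 1H-pyrrol-2-yl on an aromatic carbon. This change keeps a five-membered aromatic ring with one hetero atom at the same place, so the large step from compound 1 to compound 2 does not bear on it directly; compound 3, which also carries a five-membered aromatic ring there, differs from compound 2 in a second place as well, so its value offers only a loose hint that such rings give similar numbers. Compound 4 is therefore expected to land close to compound 2, with a step of a 1.0-fold higher number from compound 2 to compound 4 (0.02 log units; within the scatter) that stays within the scatter. The estimated value for compound 4 is 200 nM, within a range from 70 nM to 600 nM.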

Compound 4, half-maximal inhibitory concentration: 59.5 nM
For compound 4 the middle estimate is 3.4-fold (0.53 log units) above the measured one; measured number below the stated range.
By their numbers in this assay, from the lowest: compounds 4 and 3 (each within the scatter of the next); then compound 2; then compound 1.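

In this assay, the identity of the five-membered aromatic ring matters at this position, not just its being aromatic: thiophen-3-yl gives a 3.2-fold lower number from compound 2 to compound 4 (0.51 log units; beyond the scatter) in this single change. The ring that leaves has a hydrogen-bond donor and the ring that enters has none, so the donor of 1H-pyrrol-2-yl is not required for the lower number in this pair. Measured against the saturated oxolan-2-yl ring, the same thiophen-3-yl group gives a 64-fold lower number from compound 1 to compound 4 (1.81 log units; beyond the scatter) and so sets a new reference point for this position on the shared core.

On these data alone, it remains open how thiophen-3-yl would compare with thiophen-2-yl, with a six-membered pyridinyl ring, or with a thiophene ring carrying an added amine. The data offer no measured explanation for either step.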